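The source may hold more compounds than are shown below. What is called first, only, known or untested is meant among the compounds shown, and "the series" means these compounds.

In a functional assay on HepG2 cells (Homo sapiens) for antiproliferative activity, read by MTT assay, with a stated time of 72 h (a higher number here means a weaker inhibitor, a lower number a stronger inhibitor), three compounds with a shared core have been tested so far, and none of them gives a true number. Compound 1 (`O=C1COc2ccc(-c3cnc(Cl)c(NS(=O)(=O)c4ccc(F)cc4)c3)cc2N1C1CCCCC1`) reads > 40000 nM as a limit of the assay, not a number. Compound 2 (`COc1ncc(-c2ccc3c(c2)N(C2CCCCC2)C(=O)CO3)cc1NS(=O)(=O)c1ccc(F)cc1`) reads > 40000 nM as a limit too. Compound 3 (`O=C1COc2ccc(-c3cnc4ccccc4c3)cc2N1C1CCCCC1`) also reads > 40000 nM as a limit, and this is where the next step starts.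

Compound 4 (`O=C1COc2ccc(-c3cnc4ccccc4c3)cc2N1c1ccc(F)cc1`) carries 4-fluorophenyl in place of cyclohexyl on an amide-type nitrogen in a ring compared with compound 3. For the measured compounds named here, only one measured step is available, and it changes a different group: a step that the two limits leave unreadable from compound 1 to compound 2 with methoxy in place of chloro on an aromatic carbon. Going by the values given here, that step has no size to carry over, and no measured step touches this nitrogen. What remains is the limit of > 40000 nM in this assay, at which 3 of the 3 values shown sit, and this gives a flat picture with no direction in it. The estimated step is a number no higher from compound 3 to compound 4 (the limit leaves the size open) and no clear move in either direction is expected. Another limit is the likeliest report for the new compound. For compound 4 the estimated value is 40000 nM with an expected range from 15000 nM to 80000 nM in this test.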

Compound 4, half-maximal inhibitory concentration: 37200 nM
Beside the measured number, compound 4's estimate is 1.1-fold (0.03 log units) above it; low and high end bracket the measured number.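

In this assay, putting 4-fluorophenyl in place of cyclohexyl on the amide-type nitrogen in the ring gives an at least 1.0-fold lower number from compound 3 to compound 4 (0.03 log units; that floor lies within the scatter). For the compounds shown here, compound 4 is the first compound here with a true number rather than a limit, but compound 3 holds only a limit, so this step has a floor and no known upper size, and a floor within the scatter does not show that either group is better than the other. What the result does add is that this nitrogen can carry a six-membered aromatic ring and still give a readable value, although that value lies close to the edge of the range where the other compounds stop being readable: the limit of > 40000 nM in this assay, at which 3 of the 4 values shown sit.

The compounds shown leave open whether the fluorine matters at all, since plain phenyl, a small methyl group or a chain ending in an amine on this nitrogen would each test a different part of the change. They also leave open whether 4-fluorophenyl on this nitrogen would give a true number with the sulfonamide-bearing groups of compound 1 and compound 2 in place of the group that compound 4 carries.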